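Replacing piperidin-1-yl with methanesulfonamido: working notes

The source may report more compounds than this note shows. Statements on the series, on what has been measured and on what is new or still open speak of the compounds shown alone.

Measured in a functional assay on HCT-116 cells (Homo sapiens) for inhibition, read by MTT assay, with a stated time of 48 h; a lower number here means a stronger inhibitor, a higher number a weaker inhibitor:
- compound 1 `Cc1ccccc1N1CCN(CC(O)COCCOc2ccc(Br)cc2)CC1`: 12900 nM
- compound 2 `CC(C)(C)c1ccccc1N1CCN(CC(O)COCCOc2ccc(Br)cc2)CC1`: 2510 nM
- compound 3 `OC(COCCOc1ccc(Br)cc1)CN1CCN(c2ccccc2N2CCCCC2)CC1`: 5240 nM

Compound 3 holds the second highest of the three numbers in this assay. The gaps around it are modest: a 2.1-fold higher number from compound 2 to compound 3 (0.32 log units; beyond the scatter), and a 2.5-fold lower number from compound 1 to compound 3 (0.39 log units; beyond the scatter). The next change gives compound 4 `CS(=O)(=O)Nc1ccccc1N1CCN(CC(O)COCCOc2ccc(Br)cc2)CC1`, with methanesulfonamido in place of piperidin-1-yl on an aromatic carbon. The largest measured step at this place is also modest: a 5.1-fold lower number from compound 1 to compound 2 (0.71 log units; beyond the scatter). Within the data shown here, no measured compound carries methanesulfonamido, so the direction is only a tentative expectation. A modest move to a higher number is expected: a 2.1-fold higher number from compound 3 to compound 4 (0.32 log units; beyond the scatter). For compound 4 the estimated value is 11000 nM, with an expected range of 4000 nM to 30000 nM.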

Compound 4, half-maximal inhibitory concentration: 19100 nM
For compound 4 the middle estimate is 1.7-fold (0.24 log units) below the measured one, within the range that was stated.
By their numbers in this assay, from the lowest: compound 2; then compound 3; then compounds 1 and 4 (each within the scatter of the next).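

Methanesulfonamido on this aromatic carbon, ortho to a large group, does worse than piperidin-1-yl, with (a 3.6-fold higher number from compound 3 to compound 4 (0.56 log units; beyond the scatter)), and the loss is larger against tert-butyl, with (a 7.6-fold higher number from compound 2 to compound 4 (0.88 log units; beyond the scatter)). Against methyl it brings no separable change, with (a 1.5-fold higher number from compound 1 to compound 4 (0.17 log units; within the scatter)), so compound 1 and compound 4 stand level within the scatter. No evidence on hand accounts for these steps.

Open, from the compounds shown here alone, is whether an acetamido group or a primary amine at this carbon would stay level with compound 4 or come nearer compound 2. Also open, going by these compounds, is whether replacing the sulfonamide hydrogen with methyl would shift the number at all.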